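Benzoyl on the Ring Nitrogen of a Weak Antiproliferative Urea

The source may hold more compounds than are shown below. What is called first, only, known or untested is meant among the compounds shown, and "the series" means these compounds.

Compound 1: `Nc1ncnc2c1ccn2-c1ccc(NC(=O)Nc2ccc(Cl)c(C(F)(F)F)c2)cc1`, 8100 nM
Compound 2: `O=C(Nc1ccc(-n2ccc3c(NC(=O)c4ccccc4)ncnc32)cc1)Nc1cc(C(F)(F)F)cc(C(F)(F)F)c1`, 9800 nM
Compound 3: `CC(=O)Nc1ncnc2c1ccn2-c1ccc(NC(=O)Nc2cccc(Cl)c2Cl)cc1`, > 10000 nM

Three diaryl ureas sharing one core were tested in a functional assay on A375P cells (Homo sapiens) for antiproliferative activity, read by MTT assay, with a stated time of 24 h; on this read-out higher numbers stand for weaker inhibition and lower numbers for stronger inhibition. Compound 1 gives 8100 nM in this assay and compound 2 gives 9800 nM; the two values lie within the scatter of each other, so neither can be set above the other. Compound 3 sits at the limit of > 10000 nM in this assay, at which 1 of the 3 values shown sits, which is a limit rather than a number.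

The step followed here leads from compound 1 to compound 4, `O=C(Nc1ccc(-n2ccc3c(NC(=O)c4ccccc4)ncnc32)cc1)Nc1ccc(Cl)c(C(F)(F)F)c1`. The change is benzoyl in place of hydrogen on a nitrogen on an aromatic ring. Among the compounds with values here, no measured pair differs in this one place, so the size of the step is not known. A step of no more than the scatter is expected, because compound 2, which also carries benzamido in this place, gives 9800 nM, close to compound 1. The estimated step is a 1.2-fold higher number from compound 1 to compound 4 (0.07 log units; within the scatter). Compound 4 is therefore expected to give 9500 nM in this assay, between 4500 nM and 20000 nM.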

Compound 4, half-maximal inhibitory concentration: 4600 nM
Compound 4: the middle estimate sits 2.1-fold (0.31 log units) above what was measured, and the stated range covers the measured number.
By their numbers in this assay, from the lowest: compounds 4, 1 and 2 (each within the scatter of the next, the first and the last beyond it). At a limit, above all of these: compound 3.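

Within the data shown here, compound 1 and compound 4 form the first pair that differs only on this nitrogen, and in this assay the step reads a 1.8-fold lower number from compound 1 to compound 4 (0.25 log units; within the scatter). Amino and benzamido therefore cannot be told apart at this position, even though the change adds the eight heavy atoms of benzoyl, including its aromatic ring. Compound 2 also carries benzamido, but its urea bears a different aryl group, so it could not isolate this change.

No measurement shown bears on why the step has this size. On these data alone, it remains open whether a different group on this nitrogen, such as a longer alkyl chain or a morpholine ring, would produce a step beyond the scatter.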